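The compounds below may be only part of what the source reports. "The series", "measured", "known", "first", "only" and "open" are said of these compounds alone.

Measured compounds in a functional assay on HepG2 cells (Homo sapiens) for antiproliferative activity, read by MTT assay, with a stated time of 72 h; on this read-out higher numbers stand for weaker inhibition and lower numbers for stronger inhibition:

- compound 1 `FC(F)(F)c1ccc(COc2cccc(Nc3ncnc4cc5c(cc34)OCCOCCOCCOCCO5)c2)cc1`, value 5700 nM
- compound 2 `FC(F)(F)c1ccc(COc2ccc(Nc3ncnc4cc5c(cc34)OCCOCCOCCOCCO5)cc2)cc1`, value 3340 nM

On the numbers shown, compound 1 has the highest value of the two; its nearest neighbour is compound 2, and the gap between them lies within the usual scatter of this assay, so no order between the two is read from it. For the measured compounds named here, no pair of measured compounds differs in a single place, so no measured step is available.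

Compound 3 `O=[N+]([O-])c1ccc(COc2cccc(Nc3ncnc4cc5c(cc34)OCCOCCOCCOCCO5)c2)cc1` is not yet measured. It differs from compound 1 by nitro in place of trifluoromethyl on an aromatic carbon. Going by the values given here, nothing among the measured compounds shows how this assay responds to such an exchange, and the two values in hand do not separate from each other. The expectation is therefore that the step from compound 1 to compound 3 stays within the scatter, with no direction preferred. Compound 3 is estimated at 5000 nM, in the range 1500 nM to 16000 nM, which corresponds to an expected step of a 1.1-fold lower number from compound 1 to compound 3 (0.06 log units; within the scatter).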

Compound 3, half-maximal inhibitory concentration: 9820 nM
Compound 3: middle estimate off by 2.0-fold (0.29 log units), on the low side; low and high end bracket the measured number.
By their numbers in this assay, from the lowest: compounds 2, 1 and 3 (each within the scatter of the next, the first and the last beyond it).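

In this assay, for the compounds shown here, the exchange of 4-(trifluoromethyl)benzyl for 4-nitrobenzyl gives the only single-place step so far, a 1.7-fold higher number from compound 1 to compound 3 (0.24 log units; within the scatter). Going by these compounds alone, at this aromatic carbon, para to a large group, a nitro with two hydrogen-bond acceptors can thus stand in place of a trifluoromethyl with none, and the read-out does not separate from the scatter; the earlier compounds gave no view of any change at this carbon. Nothing at hand bears on the reason for this result, and the step is read here only as a size.

One exchange on the benzyl ring of compound 1 gives no trend for this position, and a wider range of groups at this carbon, such as an amine, a carboxylic acid or a longer alkyl chain, could still move the number beyond the scatter in this assay. Going by these compounds, it also remains open whether nitro in place of trifluoromethyl would give a step of similar size on the arrangement of compound 2, whose aniline ring carries its benzyl ether at a different place.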